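This account rests on a few compounds, and the source may have more. Where it says the series, first, only, none or still open, it means among the compounds named here.

Three compounds have been measured in an in vitro assay on BL21-DE3 cells for inhibition of Deoxyuridine 5'-triphosphate nucleotidohydrolase, mitochondrial (Homo sapiens); on this read-out lower numbers stand for stronger inhibition and higher numbers for weaker inhibition:

compound 1, `Cc1ccc(S(=O)(=O)OC[C@H]2O[C@@H](n3ccc(=O)[nH]c3=O)C[C@@H]2O)cc1`, > 1000000 nM
compound 2, `O=c1ccn([C@H]2C[C@H](O)[C@@H](CO[Si](c3ccccc3)(c3ccccc3)c3ccccc3)O2)c(=O)[nH]1`, 909000 nM
compound 3, `CC(=O)NCC1OC(n2ccc(=O)[nH]c2=O)CC1O`, > 1000000 nM

The value of compound 1 is a limit of the assay rather than a number. The value of compound 3 is also a limit, not a number. Within the data shown here, compound 2 is the only one with a measured number, and it lies in the region of very weak inhibition. Among the measured compounds shown here, compound 3 therefore stands at the ceiling of what can be measured, described by the limit of > 1000000 nM in this assay, at which 2 of the 3 values shown sit; nothing more precise is known about it, and no step between measured compounds can be used to calibrate a change.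

Compound 4, `CCCCC(=O)NCC1OC(n2ccc(=O)[nH]c2=O)CC1O`, differs from compound 3 by propyl in place of hydrogen on a saturated chain carbon bound to a carbonyl carbon. With compound 3 already at the limit, there is no number from which a step can be measured. The expectation is that compound 4 remains in the same very weak region, with no step beyond the usual scatter, although a move to a measurable number cannot be ruled out. In this assay compound 4 is expected to give 1000000 nM, within a range from 300000 nM to 3000000 nM. That estimate means an expected step of a number no higher from compound 3 to compound 4 (the limit leaves the size open).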

Compound 4, inhibition constant: > 1000000 nM
Compound 4: only a limit was reported; the forecaster's own chance of this, stated with the estimate: 65%; the middle value sits exactly at the limit.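

Among these compounds, compound 3 and compound 4 both sit at a limit of the assay rather than at a number, so no step between them can be read: the limit of > 1000000 nM in this assay, at which 3 of the 4 values shown sit. The compounds shown leave open how strongly these two actually inhibit the enzyme, and whether propyl in place of hydrogen changes inhibition at all.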